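A few compounds are considered here, and "the series" means these few. Any claim that something is new, unique, unknown or untested is made for them only; others in the source may bear on it.

Measured so far in a toxicity assay on NIH3T3 cells (Mus musculus) for cytotoxicity, read by resazurin assay; a lower number here means that less compound is needed, a higher number that more compound is needed for the effect:
- compound 1 `COC(=O)c1ccc(NCc2cncn2Cc2ccccc2Cl)cc1-c1ccccc1`: 10000 nM
- compound 2 `Cc1ccccc1-c1ccc(Cn2cncc2CNc2ccc(-c3nc4ccccc4s3)c(-c3ccccc3)c2)cc1`: > 1000 nM
- compound 3 `Cc1ccc(Cn2cncc2CNc2cccc(-c3ccccc3)c2)cc1`: 10000 nM

Compound 1 and compound 3 each give a number in this assay, and those two numbers lie within the usual scatter of each other, so nothing separates them. For compound 2 this assay reports only a limit, (the limit of > 1000 nM in this assay, at which 1 of the 3 values shown sits), and not a number. What is known of compound 2 is therefore only that it sits on the side of that limit which the sign shows; how far beyond it the true value lies is not known from these data.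

Compound 4 `c1ccc(-c2ccc(Cn3cncc3CNc3ccc(-c4nc5ccccc5s4)c(-c4ccccc4)c3)cc2)cc1` has not been measured in this assay. Its difference from compound 2 is hydrogen in place of methyl on an aromatic carbon. For the measured compounds named here, no measured pair shows the effect of this exact change, so the expected size of the step rests on the change alone: a single carbon leaving and a hydrogen entering, with no ring, donor, acceptor or charge involved.

For compound 4 the expected shift from compound 2 is a step that the limit leaves unreadable from compound 2 to compound 4, that is, no change beyond the scatter. The estimate for compound 4 in this assay is therefore 10000 nM, with a range from 3000 nM to 30000 nM.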

Compound 4, half-maximal effective concentration: > 1000 nM
Compound 4 was reported as a limit; the forecaster's own chance of this, stated with the estimate: 50%; the middle value lies beyond the limit too.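

In this assay compound 2 and compound 4 are both reported only as limits, so no step between them can be read: the limit of > 1000 nM in this assay, at which 2 of the 4 values shown sit.

The compounds shown leave open how far past that limit compound 2 and compound 4 lie, and whether going from 2-methylphenyl to phenyl shifts the value at all.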